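Nitro for Hydroxy on One Side of the Series

The source may hold more compounds than are shown below. What is called first, only, known or untested is meant among the compounds shown, and "the series" means these compounds.

Of the compounds shown here, two have numbers so far. In a functional assay on U-87MG ATCC cells (Homo sapiens) for cytotoxicity, read by resazurin assay, with a stated time of 48 h (on this read-out lower numbers stand for stronger inhibition and higher numbers for weaker inhibition), compound 1 (`O=C1/C(=C/c2ccc(O)cc2)CS(=O)(=O)C/C1=C\c1ccc(O)cc1`) gives 6730 nM, the higher of the two values, and compound 2 (`O=C1/C(=C/c2cccc([N+](=O)[O-])c2)CS(=O)(=O)C/C1=C\c1cccc([N+](=O)[O-])c1`) gives 760 nM. That gap lies beyond the scatter, but the two differ in more than one place, so it is not a single-change step.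

Compound 3 (`O=C1/C(=C/c2ccc(O)cc2)CS(=O)(=O)C/C1=C\c1ccc([N+](=O)[O-])cc1`) has not yet been measured. It departs from compound 1 at one place, with nitro in place of hydroxy on an aromatic carbon, so that one 4-hydroxyphenyl becomes 4-nitrophenyl: nitro in place of hydroxy on an aromatic carbon. Going by the values given here, compound 2 also carries nitro, but not at this place, and no matched pair yet shows this change alone.

Compound 3 is expected to fall between its two measured relatives, since compound 2 at 760 nM is the only nitro-bearing reference. The expected change is a moderate move towards stronger inhibition, estimated as a 3.1-fold lower number from compound 1 to compound 3 (0.49 log units; beyond the scatter). Compound 3 is estimated at 2200 nM, with an expected range of 800 nM to 6000 nM.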

Compound 3, half-maximal inhibitory concentration: 2170 nM
The estimate for compound 3 lay 1.0-fold (0.01 log units) above the measured number; the measured number falls inside the stated range.
By their numbers in this assay, from the lowest: compound 2; then compound 3; then compound 1.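

In this assay, going by these compounds alone, the swap of 4-hydroxyphenyl for 4-nitrophenyl on one side alone gives a 3.1-fold lower number from compound 1 to compound 3 (0.49 log units; beyond the scatter), the first single-change step and one that lies beyond the scatter. This shows that this place on the aromatic ring, para to a large group, responds to the change by itself, with the second 4-hydroxyphenyl and the shared core left as they are in compound 1. No measured property of these compounds bears on the origin of this step, so the step stands as an observation only.

The compounds shown do not tell whether the step belongs to nitro in particular or would also appear with another group at the same place, such as an amine, a carboxylic acid or a methoxy group. They also leave open whether the same change on the second 4-hydroxyphenyl of compound 3 would add a further step of like size, since a single matched pair gives no indication of how changes on the two sides combine.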